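Halogenated aryl swap on a diketopiperazine-type bis-arylidene core

A few compounds are considered here, and "the series" means these few. Any claim that something is new, unique, unknown or untested is made for them only; others in the source may bear on it.

For the measured compounds named here, compound 3 `C=CCn1c(=O)/c(=C\c2ccccc2Cl)[nH]c(=O)/c1=C\c1ccccc1OC` is the only member of this small set with a number: in a functional assay on MOLT-4 cells (Homo sapiens) for cytotoxicity, read by CCK-8 assay, with a stated time of 72 h (on this read-out higher numbers stand for weaker inhibition and lower numbers for stronger inhibition), compound 3 gives 4400 nM, and so it stands alone rather than at either end of any ranking. Compound 1 `COc1ccccc1/C=c1/[nH]c(=O)/c(=C\c2ccccc2OC)n(C)c1=O` in this assay is recorded as "not determined" (no result reported), and compound 2 `COc1ccccc1/C=c1/[nH]c(=O)/c(=C\c2cccc(Cl)c2Cl)[nH]c1=O` is likewise recorded as "not determined" (no result reported). Compound 4 `C=CCn1c(=O)/c(=C\c2cc(Br)ccc2F)[nH]c(=O)/c1=C\c1ccccc1OC` differs from compound 3 in one place, (5-bromo-2-fluorophenyl in place of 2-chlorophenyl on a double-bonded chain carbon bound to an aromatic carbon). Going by the values given here, no comparable pair has been measured, so the size of this step is unknown; an exchange of one halogenated phenyl for another is expected to shift this assay little, probably not beyond the scatter. Compound 4 is therefore estimated at 4000 nM, within 1500 nM to 12000 nM, an expected step from compound 3 to compound 4 of a 1.1-fold lower number from compound 3 to compound 4 (0.04 log units; within the scatter).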

Compound 4, half-maximal inhibitory concentration: 12900 nM
Beside the measured number, compound 4's estimate is 3.2-fold (0.51 log units) below it; measured number above the stated range.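

In this assay, the exchange gives a 2.9-fold higher number from compound 3 to compound 4 (0.47 log units; beyond the scatter), which shows that this position distinguishes between one halogenated phenyl and another. For the compounds shown here, it is the only change here that can be read, as compound 1 and compound 2 carry no number. Nothing measured here accounts for the step.
Because 5-bromo-2-fluorophenyl differs from 2-chlorophenyl in both its halogens and their arrangement, the compounds shown leave open how much each contributes. They also leave open how a phenyl bearing an amine or a carboxylic acid would read at this place.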